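This account rests on a few compounds, and the source may have more. Where it says the series, first, only, none or still open, it means among the compounds named here.

Three compounds with a shared core were taken into a functional assay on HeLa cells (Homo sapiens) for cytotoxicity, read by WST assay, with a stated time of 48 h; on this read-out lower numbers stand for an effect already at smaller amounts and higher numbers for an effect only at larger amounts of compound: compound 1 (`COc1cc(C[C@H]2C(=O)OC[C@@H]2Cc2ccccc2)ccc1O`), compound 2 (`O=C1OC[C@H](Cc2ccccc2)[C@H]1Cc1cc(Cl)cc(Cl)c1`) and compound 3 (`Cc1cccc(C[C@H]2COC(=O)[C@@H]2Cc2ccc(Cl)c(Cl)c2)c1`). Only one of them gave a number, with compound 2 at 17000 nM. The entry for compound 1 reads "not determined" (no result reported), and the entry for compound 3 also reads "not determined" (no result reported). Among the measured compounds shown here, compound 3 therefore has no place on the scale, and there is no measured step to lean on.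

Compound 4 (`O=C1OC[C@H](Cc2ccc(F)cc2)[C@H]1Cc1ccc(Cl)c(Cl)c1`) differs from compound 3 in one group: 4-fluorophenyl in place of 3-methylphenyl on a saturated chain carbon bound to a saturated ring carbon. The change sits on a saturated chain carbon bound to a saturated ring carbon. For the measured compounds named here, with no number for compound 3, no step of a definite size or direction can be argued in this assay, so none beyond the usual scatter is expected from the only available anchor, compound 2 at 17000 nM. A report without a number would also not be surprising. For compound 4 the estimated value is 15000 nM, with an expected range from 5000 nM to 50000 nM.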

Compound 4, half-maximal effective concentration: 19000 nM
Beside the measured number, compound 4's estimate is 1.3-fold (0.10 log units) below it; low and high end bracket the measured number.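

Among the compounds shown here, with no single number for compound 3, no step from it to compound 4 can be read. The compounds shown leave open whether 4-fluorophenyl in place of 3-methylphenyl changes the result at all in this assay and no evidence at hand bears on this result.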